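Swapping propyl for cyclopropyl on a tight binder

The source may report more compounds than this note shows. Statements on the series, on what has been measured and on what is new or still open speak of the compounds shown alone.

In a functional assay (aorta) with Oryctolagus cuniculus as the target (on this read-out lower numbers stand for tighter binding and higher numbers for weaker binding), compound 2 `CCCc1nc2c(C)ccnc2n1Cc1cc(Cl)c(O)c(Cl)c1` gives 1.26 nM. Compound 1 `Oc1c(Cl)cc(Cn2c(C3CC3)nc3cccnc32)cc1Cl` gives 20 nM, so compound 2 has the lower of the two numbers, by a gap beyond the usual scatter. Compound 3 `Cc1ccnc2c1nc(C1CC1)n2Cc1cc(Cl)c(O)c(Cl)c1` has not yet been measured. It has cyclopropyl in place of propyl on an aromatic carbon of compound 2 (cyclopropyl in place of propyl on an aromatic carbon). Going by the values given here, no measured pair shows this change on its own. Compound 1 also carries cyclopropyl and gives 20 nM, but it differs from compound 2 in more than one place, so it offers only a weak hint. In this assay, a modest rise towards weaker binding is expected, a 2.4-fold higher number from compound 2 to compound 3 (0.38 log units; beyond the scatter), and this estimated step may prove no larger than the scatter. For compound 3 the estimated value is 3 nM, with an expected range from 0.8 nM to 12 nM.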

Compound 3, dissociation constant: 2 nM
The estimate for compound 3 lay 1.5-fold (0.18 log units) above the measured number; low and high end bracket the measured number.
By their numbers in this assay, from the lowest: compounds 2 and 3 (each within the scatter of the next); then compound 1.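

In this assay, cyclopropyl in place of propyl on the aromatic carbon between two ring nitrogen atoms gives a 1.6-fold higher number from compound 2 to compound 3 (0.20 log units; within the scatter), so closing these three carbons into a ring makes no clear difference at this position. With cyclopropyl held constant, methyl in place of hydrogen on an aromatic carbon gives a 10-fold lower number from compound 1 to compound 3 (1.00 log units; beyond the scatter), so among these compounds the clear change in the read-out goes with the methyl rather than with the swap from propyl to cyclopropyl. Nothing measured here explains either result.

Going by these compounds, the methyl step can be read only alongside cyclopropyl, so its size alongside propyl remains open. Also unknown is how a longer chain, such as pentyl, or an amine would behave on the carbon that holds propyl or cyclopropyl.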